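Two Isomeric Acyl Chains in an Antiproliferative Series

This account rests on a few compounds, and the source may have more. Where it says the series, first, only, none or still open, it means among the compounds named here.

Measured compounds:
compound 1 `CC(C)=CC(=O)Nc1cccc(Oc2nc(Nc3cccc(C#N)c3)nc3c2CSCC3)c1` gives 36900 nM in cell testing
compound 2 `CC/C=C/C(=O)Nc1cccc(Oc2nc(Nc3ccc(OC)cc3)nc3c2CSCC3)c1` gives 20100 nM in cell testing

Among the measured compounds shown here, both numbers come from a functional assay on A549 cells (Homo sapiens) for antiproliferative activity, read by MTT assay, with a stated time of 72 h (on this read-out lower numbers stand for stronger inhibition and higher numbers for weaker inhibition), and are the only measurements available so far. Compound 2 stands at 20100 nM on this scale and compound 1 at 36900 nM on the same scale, and these two values lie within the usual scatter of each other. Neither compound can therefore be placed ahead of the other.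

Compound 3 `COc1ccc(Nc2nc3c(c(Oc4cccc(NC(=O)C=C(C)C)c4)n2)CSCC3)cc1` has not yet been measured. It has the same atoms as compound 2, joined differently at one place 2-methylprop-1-en-1-yl in place of but-1-en-1-yl on a carbonyl carbon on a carbonyl carbon, where 2-methylprop-1-en-1-yl stands in place of but-1-en-1-yl. For the measured compounds named here, no measured pair shows a step of this kind, so the data give no direct guide to its effect in this assay and no direction can be argued. The step of a 1.2-fold higher number from compound 2 to compound 3 (0.08 log units; within the scatter) is expected to stay within the usual scatter. Compound 3 is estimated at 24000 nM (expected range 10000 nM to 50000 nM).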

Compound 3, half-maximal inhibitory concentration: 26900 nM
Estimate against measurement, compound 3: 1.1-fold (0.05 log units) below; the measured number falls inside the stated range.
By their numbers in this assay, from the lowest: compounds 2, 3 and 1 (each within the scatter of the next).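

In this assay, putting 2-methylprop-1-en-1-yl in place of but-1-en-1-yl on the carbonyl carbon gives a 1.3-fold higher number from compound 2 to compound 3 (0.13 log units; within the scatter), so with the 4-methoxyphenyl group shared, these two isomeric chains cannot be told apart. Compound 3 also links the series in a way that compounds 1 and 2 could not, since they differ in two places: with the 2-methylprop-1-en-1-yl chain shared, 4-methoxyphenyl in place of 3-cyanophenyl on a nitrogen on an aromatic ring gives a 1.4-fold lower number from compound 1 to compound 3 (0.14 log units; within the scatter), and this change also stays within the scatter. No other kind of measurement is available to bear on these results.

Going by these compounds, it remains open whether a chain of a different kind on the carbonyl carbon, such as a saturated butyl chain or a chain carrying an amine, would move the number beyond the scatter. On these data alone, it is equally open whether a different group on the nitrogen, such as a phenyl ring carrying a carboxylic acid, would do so, and whether but-1-en-1-yl and 2-methylprop-1-en-1-yl would also match when paired with 3-cyanophenyl.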